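Swapping 4-hydroxyphenyl for 2,6-dimethoxyphenyl

This account rests on a few compounds, and the source may have more. Where it says the series, first, only, none or still open, it means among the compounds named here.

Compound 1 `O=C(Cc1csc2nc(-c3ccc(Br)cc3)cn12)N/N=C/c1ccccc1` and compound 2 `O=C(Cc1csc2nc(-c3ccc(Br)cc3)cn12)N/N=C/c1ccc(O)cc1` share the same core and differ by a single group, hydroxy in place of hydrogen on an aromatic carbon. In a functional assay on HCT-116 cells (Homo sapiens) for inhibition, read by sulforhodamine B assay, with a stated time of 48 h (on this read-out lower numbers stand for stronger inhibition of growth and higher numbers for weaker inhibition of growth), compound 1 gives 21400 nM and compound 2 gives 24000 nM. Within the data shown here, these are the only two numbers so far, and compound 2 stands within the scatter of compound 1, so the pair cannot be ranked.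

Compound 3 `COc1cccc(OC)c1/C=N/NC(=O)Cc1csc2nc(-c3ccc(Br)cc3)cn12` carries a larger change, with 2,6-dimethoxyphenyl in place of 4-hydroxyphenyl on a carbon with a double bond to nitrogen. Among the measured compounds shown here, only one measured step bears on this change: a 1.1-fold higher number from compound 1 to compound 2 (0.05 log units; within the scatter). It touches the same aromatic ring and stays within the scatter. For the measured compounds named here, it is weak guidance, as no measured compound carries a methoxy group. No step beyond the scatter is therefore expected in this assay, and the estimated step is a 1.0-fold lower number from compound 2 to compound 3 (0.02 log units; within the scatter). For compound 3 the expected value is 23000 nM, with an estimated range from 10000 nM to 50000 nM.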

Compound 3, concentration for total growth inhibition: 15800 nM
The estimate for compound 3 lay 1.5-fold (0.16 log units) above the measured number; low and high end bracket the measured number.
By their numbers in this assay, from the lowest: compounds 3, 1 and 2 (each within the scatter of the next).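

The earlier pair tested only a hydroxy group on the aromatic ring attached to the carbon with a double bond to nitrogen. Compound 3 puts a far more different group at this place: 2,6-dimethoxyphenyl has more heavy atoms than 4-hydroxyphenyl and no hydrogen-bond donor, yet in this assay the numbers cannot be told apart, both against the hydroxy compound (a 1.5-fold lower number from compound 2 to compound 3 (0.18 log units; within the scatter)) and against the plain phenyl compound (a 1.4-fold lower number from compound 1 to compound 3 (0.13 log units; within the scatter)). So across these three compounds, neither the hydrogen-bond donor of 4-hydroxyphenyl nor the two methoxy groups separates one compound from another on this read-out, and no available data offer an explanation for this.

Going by these compounds, whether any group at this place can move the number beyond the scatter remains open, for instance an amine or a carboxylic acid on the ring, or a longer chain in place of the ring. On these data alone, the three compounds also share the 4-bromophenyl group on the core, so what happens when bromine gives way to chlorine or to a methoxy group stays unknown.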